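The compounds below may be only part of what the source reports. "The series", "measured", "known", "first", "only" and "open" are said of these compounds alone.

Compound 1 `Cc1cc(NC(=O)Nc2cccc(F)c2)c2ccccc2n1` gives > 25000 nM in an ADME assay on Raji cells (Homo sapiens) for cytotoxicity, with a stated time of 72 h (on this read-out lower numbers stand for an effect already at smaller amounts and higher numbers for an effect only at larger amounts of compound), a limit of the assay rather than a number.
Compound 2 `COc1ccc(NC(=O)Nc2cc(C)nc3ccccc23)cc1F` gives > 25000 nM, again only a limit.

Compound 1 therefore stands only at the limit (the limit of > 25000 nM in this assay, at which 2 of the 2 values shown sit). For the measured compounds named here, the one step measured, a step that the two limits leave unreadable from compound 1 to compound 2, cannot be read from two limits. Compound 3 `Cc1cc(NC(=O)Nc2ccc(N)cc2)c2ccccc2n1` differs from compound 1 by 4-aminophenyl in place of 3-fluorophenyl on an amide-type nitrogen. Going by the values given here, no measured step bears on this change, and the two limits give no direction. Compound 3 is expected to remain near the limit, with a step that the limit leaves unreadable from compound 1 to compound 3 estimated as none beyond the scatter. The estimate for compound 3 is 30000 nM, ranging from 8000 nM to 100000 nM.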

Compound 3, half-maximal effective concentration: > 25000 nM
Compound 3 gave a limit, no number (the forecaster's own chance of this, stated with the estimate: 70%); the middle value is on the limit's open side.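

For the compounds shown here, compound 3, like compound 1, gives only a limit, so no step between them can be read: the limit of > 25000 nM in this assay, at which 3 of the 3 values shown sit.
The compounds shown leave open how far any of them lies beyond that limit in this assay and whether any change on the shared core alters the read-out.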